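A few compounds are considered here, and "the series" means these few. Any claim that something is new, unique, unknown or untested is made for them only; others in the source may bear on it.

Working notes on the series. In a physicochemical assay, with a stated time of 6 min (a higher number here means a weaker inhibitor, a lower number a stronger inhibitor), compound 1 (`O=C(Nc1ccc(F)cc1)Nc1nc(-c2cc3ccccc3o2)cs1`) gives 1130 nM and holds the lowest number of the set. Compound 2 (`O=C(Nc1ccccc1)Nc1nc(-c2cc3cc([N+](=O)[O-])ccc3o2)cs1`) gives 183000 nM as the nearest other number, a gap beyond the scatter. Compound 3 (`O=C(Nc1ccc([N+](=O)[O-])cc1)Nc1nc(-c2cc3cc(Br)ccc3o2)cs1`) reads > 200000 nM in this assay and this is a limit, not a number.

Compound 4 (`O=C(Nc1nc(-c2cc3ccccc3o2)cs1)Nc1ccccc1[N+](=O)[O-]`) is still unmeasured. It keeps the core of compound 1 and carries 2-nitrophenyl in place of 4-fluorophenyl on an amide-type nitrogen, counted in full as 2-nitrophenyl in place of 4-fluorophenyl on an amide-type nitrogen for this change.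

Going by the values given here, no measured pair isolates such a swap, so the expectation rests on indirect evidence. Compound 2 carries a nitro group and stands at 183000 nM in this assay, and compound 3 carries one too. Both also differ from compound 1 in the core, so their high readings cannot be assigned to the nitro group alone. An upward step beyond the scatter is therefore expected, though a smaller one than the full gap to compound 2. The estimated move is an 11-fold higher number from compound 1 to compound 4 (1.03 log units; beyond the scatter) in the direction of weaker inhibition. Compound 4 is estimated at 12000 nM with an expected range of 2000 nM to 90000 nM in this assay for now.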

Compound 4, half-maximal inhibitory concentration: 20300 nM
Beside the measured number, compound 4's estimate is 1.7-fold (0.23 log units) below it; the range from low to high includes it.
By their numbers in this assay, from the lowest: compound 1; then compound 4; then compound 2. At a limit, above all of these: compound 3.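

In this assay, going by these compounds alone, with the core of compound 1 held fixed, 2-nitrophenyl in place of 4-fluorophenyl on an amide-type nitrogen gives an 18-fold higher number from compound 1 to compound 4 (1.25 log units; beyond the scatter), the only single-place step and one in the direction of weaker inhibition. This shows that the group on this nitrogen moves the reading on its own, with no change in the core; compound 2 and compound 3 each differ from compound 1 in the core as well, and could not show this. Nothing measured in the set speaks to why this swap produces a step of this size.

The swap removes the fluorine and brings in the nitro group in a single change, and the compounds shown do not tell which of the two carries the step. Going by these compounds, how the shared core reads with an amine or a carboxylic acid on this phenyl ring also stays open, as does whether any group on this nitrogen can bring the number below that of compound 1.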